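Fluoro to nitro: estimating compound 3

The source may hold more compounds than are shown below. What is called first, only, known or untested is meant among the compounds shown, and "the series" means these compounds.

In an ADME assay on Vero cells (Chlorocebus sabaeus) for cytotoxicity, read by resazurin assay, with a stated time of 72 h (a higher number here means a weaker inhibitor, a lower number a stronger inhibitor), compound 2 (`O=C(CCN1CCN(c2ccc(F)cc2)CC1)c1ccc(OC(F)(F)F)cc1`) gives 70300 nM. Compound 1 (`O=C(CCN1CCN(c2ccc([N+](=O)[O-])cc2)CC1)c1ccc(F)cc1`) gives 111000 nM, and the two numbers lie within the usual scatter of each other. Compound 3 (`O=C(CCN1CCN(c2ccc([N+](=O)[O-])cc2)CC1)c1ccc(OC(F)(F)F)cc1`) puts nitro in place of fluoro on an aromatic carbon of compound 2, para to a large group: nitro in place of fluoro on an aromatic carbon. Among the measured compounds shown here, no measured pair shows this change alone, but compound 1 already carries the 4-nitrophenyl and gives 111000 nM. The expected step of a 1.1-fold higher number from compound 2 to compound 3 (0.06 log units; within the scatter) in this assay therefore stays within the scatter, with no clear direction. Compound 3 is estimated at 80000 nM, with a range of 35000 nM to 170000 nM.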

Compound 3, half-maximal inhibitory concentration: 93200 nM
Estimate against measurement, compound 3: 1.2-fold (0.07 log units) below; low and high end bracket the measured number.
By their numbers in this assay, from the lowest: compounds 2, 3 and 1 (each within the scatter of the next).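

In this assay, nitro in place of fluoro on the aromatic carbon para to a large group gives a 1.3-fold higher number from compound 2 to compound 3 (0.12 log units; within the scatter) and so makes no readable difference here. Trifluoromethoxy in place of fluoro, the other single change now available, gives a 1.2-fold lower number from compound 1 to compound 3 (0.08 log units; within the scatter) and also makes no readable difference. No measurement of any other property bears on these results. Going by these compounds, whether an amine or a carboxylic acid on that aromatic carbon would give a number beyond the scatter remains open, as does the effect of a longer chain in the shared core.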